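The source may hold more compounds than are shown below. What is called first, only, known or untested is meant among the compounds shown, and "the series" means these compounds.

Measured in a functional assay on KB cells (Homo sapiens) for antiproliferative activity, read by sulforhodamine B assay, with a stated time of 3 days; on this read-out higher numbers stand for weaker inhibition of growth and lower numbers for stronger inhibition of growth:
compound 1 `Cn1ccnc1NC(=O)c1cccc(Nc2ncc(F)c(Nc3ccc(F)cc3)n2)c1` gives 14600 nM
compound 2 `CN(C)CC(=O)Nc1cccc(Nc2ncc(F)c(Nc3ccc(F)cc3)n2)c1` gives 1260 nM
compound 3 `O=C(Nc1cc(Cl)cc(Cl)c1)c1cccc(Nc2ncc(F)c(Nc3ccc(F)cc3)n2)c1` gives 20100 nM

Compound 3 has the highest number of the three in this assay; compound 1 lies within the scatter of it, compound 2 far apart. Compound 4 `O=C(Nc1cccc(Nc2ncc(F)c(Nc3ccc(F)cc3)n2)c1)c1cnccn1` differs from compound 3 by ((pyrazin-2-yl)carbonyl)amino in place of (3,5-dichlorophenyl)carbamoyl on an aromatic carbon. Among the measured compounds shown here, two measured steps bear on this. Exchanging one aromatic substituent on the amide-type nitrogen for another, a 1.4-fold higher number from compound 1 to compound 3 (0.14 log units; within the scatter), left the number essentially unchanged. The change to (((dimethylamino)methyl)carbonyl)amino, a 16-fold higher number from compound 2 to compound 3 (1.20 log units; beyond the scatter), shows that a carbonyl-bearing amino group at this aromatic carbon can move the number strongly. The entering ((pyrazin-2-yl)carbonyl)amino shares that attachment with compound 2 but keeps an aromatic ring as in compounds 1 and 3, so a moderate fall is expected for compound 4, a 2.9-fold lower number from compound 3 to compound 4 (0.46 log units; beyond the scatter). Compound 4 is estimated at 7000 nM, within 2000 nM to 25000 nM.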

Compound 4, concentration for 50% growth inhibition: 23600 nM
For compound 4 the middle estimate is 3.4-fold (0.53 log units) below the measured one; low and high end bracket the measured number.
By their numbers in this assay, from the lowest: compound 2; then compounds 1, 3 and 4 (each within the scatter of the next).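

The carbonylamino attachment shared with compound 2 does not by itself bring that compound's low number: with pyrazin-2-yl on the carbonyl carbon, the step is large (a 19-fold higher number from compound 2 to compound 4 (1.27 log units; beyond the scatter)). Compound 4 instead falls within the scatter of both carbamoyl compounds (a 1.2-fold higher number from compound 3 to compound 4 (0.07 log units; within the scatter); a 1.6-fold higher number from compound 1 to compound 4 (0.21 log units; within the scatter)), so among these four only compound 2, with its (dimethylamino)methyl group, stands apart. No evidence on hand accounts for this gap. Still open, going by these compounds, is whether the dimethylamino nitrogen itself matters; a pyrrolidine, a primary amine or a longer chain ending in dimethylamino on the same carbonyl would separate amine from chain.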